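The source may report more compounds than this note shows. Statements on the series, on what has been measured and on what is new or still open speak of the compounds shown alone.

Compound 1 `COc1ccc(Cn2nncc2-c2cc(OC)c(OC)c(OC)c2)cc1Br` and compound 2 `COc1ccc(Cn2cc(-c3cc(OC)c(OC)c(OC)c3)nn2)cc1Br` carry the same groups, arranged differently on the shared core. In a functional assay on K562 cells (Homo sapiens) for cytotoxicity, read by MTT assay, with a stated time of 5 days (on this read-out higher numbers stand for weaker inhibition and lower numbers for stronger inhibition), compound 1 gives > 10000 nM, which is a limit of the assay and not a number. Compound 2 gives > 10000 nM, which is also a limit. Everything measured so far is therefore (the limit of > 10000 nM in this assay, at which 2 of the 2 values shown sit), and compound 2 has no exact number to start from.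

Compound 3 `COc1ccc(Cn2cc(-c3cc(OC)c(OC)c(OC)c3)nn2)cc1N` differs from compound 2 in one place: amino in place of bromo on an aromatic carbon. Within the data shown here, no measured pair shows what this swap does in this assay, so any forecast is uncertain. Among the measured compounds shown here, the only anchor is compound 2 at > 10000 nM, so the expectation stays cautious. A small move towards stronger inhibition is expected, and compound 3 may well return only a limit again. The expected change, an at least 1.6-fold lower number from compound 2 to compound 3 (0.22 log units; that floor lies within the scatter), is modest. For compound 3 the estimated value is 6000 nM, with an expected range of 800 nM to 20000 nM.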

Compound 3, half-maximal inhibitory concentration: > 10000 nM
Compound 3 was reported as a limit; the forecaster's own chance of this, stated with the estimate: 50%; middle value at least 1.6-fold (0.22 log units) from the limit.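

Compound 3 gives > 10000 nM in this assay, which is again a limit and not a number, so the change from compound 2 to compound 3 cannot be read as a step. The compounds shown leave open whether amino in place of bromo, or the different arrangement in compound 1 and compound 2, changes cytotoxicity at all.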